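This account rests on a few compounds, and the source may have more. Where it says the series, first, only, none or still open, it means among the compounds named here.

Measured compounds:
- compound 1 `Cc1cc(Nc2cc(-c3ccccc3)[nH]n2)n2nc(SCc3ccc([N+](=O)[O-])cc3)nc2n1` — 4250 nM
- compound 2 `Cc1cc(Nc2cc(-c3ccccc3)[nH]n2)n2nc(SCc3nc4ccccc4[nH]3)nc2n1` — 1790 nM
- compound 3 `Cc1cc(Nc2cc(-c3ccccc3)[nH]n2)n2nc(SCc3ccc(F)cc3)nc2n1` — 3270 nM

All three share the same core and differ only in the group carried on the saturated chain carbon bound to a sulfur. In a functional assay on MGC-803 cells (Homo sapiens) for inhibition, read by MTT assay, with a stated time of 72 h (a higher number here means a weaker inhibitor, a lower number a stronger inhibitor), compound 3 gives 3270 nM, the second highest of the three numbers; its nearest neighbour is compound 1, separated by a 1.3-fold lower number from compound 1 to compound 3 (0.11 log units; within the scatter), and the furthest is compound 2, separated by a 1.8-fold higher number from compound 2 to compound 3 (0.26 log units; within the scatter). The spread of the whole set is narrow: the largest step seen, a 2.4-fold lower number from compound 1 to compound 2 (0.38 log units; beyond the scatter), is only modest.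

Compound 4 `CCCSc1nc2nc(C)cc(Nc3cc(-c4ccccc4)[nH]n3)n2n1` continues this exchange at the same position: ethyl in place of 4-fluorophenyl on a saturated chain carbon bound to a sulfur. Among the measured compounds shown here, the steps that bear on it are the two changes already made at that carbon, a 2.4-fold lower number from compound 1 to compound 2 (0.38 log units; beyond the scatter) and a 1.8-fold higher number from compound 2 to compound 3 (0.26 log units; within the scatter); both replace one aromatic ring with another, so the move to a short chain has no direct precedent here. For the measured compounds named here, since every substitution at this place so far stayed within or just beyond the scatter, the expectation is for a change of similar size, with no confident direction, and a slightly higher number is estimated as the more likely outcome.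

Compound 4 is therefore expected at 4200 nM, within 1800 nM to 10000 nM, which would mean an estimated step of a 1.3-fold higher number from compound 3 to compound 4 (0.11 log units; within the scatter).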

Compound 4, half-maximal inhibitory concentration: 12600 nM
Compound 4: the middle estimate sits 3.0-fold (0.48 log units) below what was measured, outside the stated range (above it).
By their numbers in this assay, from the lowest: compounds 2, 3 and 1 (each within the scatter of the next, the first and the last beyond it); then compound 4.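

In this assay, among the compounds shown here, this position proves less tolerant than the earlier compounds suggested: with ethyl in place of the ring-bearing group on a saturated chain carbon bound to a sulfur, each of the three comparisons moves to a higher number beyond the scatter (a 3.9-fold higher number from compound 3 to compound 4 (0.59 log units; beyond the scatter); a 3.0-fold higher number from compound 1 to compound 4 (0.47 log units; beyond the scatter); a 7.0-fold higher number from compound 2 to compound 4 (0.85 log units; beyond the scatter)), making compound 4 the weakest inhibitor of the four. All three of these steps exceed the largest exchange between ring-bearing groups (a 2.4-fold lower number from compound 1 to compound 2 (0.38 log units; beyond the scatter)), so among these four compounds the presence of a ring at this place counts for more than which ring it is, and no compound goes against this. The data offer no measured explanation for the loss.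

The step from 4-fluorophenyl to ethyl removes the ring and shortens the group together, so the two changes cannot be told apart in compounds 3 and 4. A longer chain such as hexyl, an unsubstituted benzyl, or a propyl chain ending in an amine or a carboxylic acid would show whether the ring itself or only the size of the group governs the number at this place.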